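Notes on the step from compound 3 to compound 4

The source may hold more compounds than are shown below. What is called first, only, known or untested is meant among the compounds shown, and "the series" means these compounds.

- compound 1 `COc1cc(-c2nc3ccccc3s2)ccc1OCC(=O)NNC(=O)CN[C@@H](CS(=O)(=O)O)C(=O)O` gives 1870 nM
- compound 2 `CCOC(=O)[C@H](NCC(=O)NNC(=O)COc1ccc(-c2nc3ccccc3s2)cc1OC)[C@@H](C)CC` gives 2900 nM
- compound 3 `CCOC(=O)[C@H](CS)N(CC(=O)NNC(=O)COc1ccc(-c2nc3ccccc3s2)cc1OC)C(C)=O` gives 1890 nM

All three values come from a functional assay on MCF7 cells (Homo sapiens) for inhibition, read by MTT assay, with a stated time of 3 days (a lower number here means a stronger inhibitor, a higher number a weaker inhibitor), and are read as half-maximal inhibitory concentrations. Compound 3 stands within the scatter of both other compounds. The measured gaps are a 1.0-fold higher number from compound 1 to compound 3 (0.00 log units; within the scatter) and a 1.5-fold lower number from compound 2 to compound 3 (0.19 log units; within the scatter) (both small).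

Compound 4 `CCOC(=O)[C@@H]1CCCN1CC(=O)NNC(=O)COc1ccc(-c2nc3ccccc3s2)cc1OC` has not yet been measured. It carries 2-(ethoxycarbonyl)pyrrolidin-1-yl in place of acetyl(1-(ethoxycarbonyl)-2-sulfanylethyl)amino on a saturated chain carbon bound to a carbonyl carbon.

The most relevant evidence is the earlier exchange of this same substituent, seen in a 1.5-fold lower number from compound 2 to compound 3 (0.19 log units; within the scatter) and in a 1.6-fold higher number from compound 1 to compound 2 (0.19 log units; within the scatter) (the second on an amine nitrogen). Neither exchange moved the number beyond the scatter, even though the groups differ considerably. For the measured compounds named here, no measured compound carries the 2-(ethoxycarbonyl)pyrrolidin-1-yl group, and the three values give no direction for it. A step beyond the scatter is therefore not expected in this assay, although the range is kept wide. The expected size is a 1.2-fold higher number from compound 3 to compound 4 (0.07 log units; within the scatter) (an estimate, with neither direction firmly favoured). For compound 4 the estimate is 2200 nM (expected range 1000 nM to 4800 nM).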

Compound 4, half-maximal inhibitory concentration: 770 nM
Beside the measured number, compound 4's estimate is 2.9-fold (0.46 log units) above it; the measured number lies below the stated range.
By their numbers in this assay, from the lowest: compound 4; then compounds 1, 3 and 2 (each within the scatter of the next).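

In this assay, the saturated chain carbon bound to a carbonyl carbon proves sensitive to the group it carries, since 2-(ethoxycarbonyl)pyrrolidin-1-yl gives steps beyond the scatter from all three earlier compounds (a 2.5-fold lower number from compound 3 to compound 4 (0.39 log units; beyond the scatter); a 3.8-fold lower number from compound 2 to compound 4 (0.58 log units; beyond the scatter); a 2.4-fold lower number from compound 1 to compound 4 (0.39 log units; beyond the scatter)). Compounds 1, 2 and 3 lie within the scatter of one another despite their very different groups, so they gave no sign of this, and compound 4 is now the strongest inhibitor of the four. Among these compounds, only compound 4 holds this nitrogen in a five-membered non-aromatic ring, but no measurement here accounts for the step.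

On these data alone, it remains open whether the step follows the ring itself or the ring together with its ethoxycarbonyl group, which a plain pyrrolidin-1-yl group or a free carboxylic acid on the same ring would separate. Also open, as far as these compounds go, is how far the ring size matters, for which a six-membered piperidin-1-yl ring bearing the same ethoxycarbonyl group would be the direct comparison.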